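The source may hold more compounds than are shown below. What is called first, only, known or untested is meant among the compounds shown, and "the series" means these compounds.

Three compounds have been examined in an ADME assay on Vero cells (Chlorocebus sabaeus) for cytotoxicity, with a stated time of 72 h, tested at 50 ug/mL; on this read-out higher numbers stand for a stronger effect at the one concentration tested and lower numbers for a weaker effect. Compound 1, with the structure `O=c1[nH]nc2n(c1=O)CCN2c1ccccc1`, gives 30% in this assay. Compound 2, whose structure is `Cc1ccc(N2CCN/C2=N\N)cc1`, gives 9% in this assay, and compound 3, with the structure `N/N=C1\NCCN1c1cccc(Cl)c1`, gives 10%. On these numbers compound 1 stands highest of the three: its nearest neighbour is compound 3, whose number lies beyond the usual scatter below it, and the furthest is compound 2, also beyond the scatter below it. Compound 2 and compound 3 differ from compound 1 in their cores, so their numbers are noted only for what they show.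

Compound 4, with the structure `Cc1ccc(N2CCn3c2n[nH]c(=O)c3=O)cc1`, has not yet been measured in this assay. It differs from compound 1 in one place: methyl in place of hydrogen on an aromatic carbon. Among the measured compounds shown here, no measured pair in the set shows such a change on a shared core, so there is nothing to calibrate its effect. A small change of this kind is expected to move the number, if at all, by no more than the scatter, in either direction. The step is estimated to be a number 2 percentage points higher from compound 1 to compound 4 (within the scatter). Compound 4 is therefore expected to give about 32% in this assay, within a range from 15% to 50%.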

Compound 4, a percentage reported as inhibition, at one concentration (the size of the read-out at that concentration, not a potency): 0%
Beside the measured number, compound 4's estimate is 32 percentage points above it; measured number outside the range, below it.
By their numbers in this assay, from the lowest: compounds 4, 2 and 3 (each within the scatter of the next); then compound 1.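

In this assay, among the compounds shown here, methyl in place of hydrogen on an aromatic carbon, para to a large group, gives a number 30 percentage points lower from compound 1 to compound 4 (beyond the scatter) on the shared core, the first pair in the set that isolates a single change. It shows that this place on the six-membered aromatic ring of carbon only is not indifferent to the addition of one heavy atom: compound 1 gives 30% and the read-out of compound 4, at 0%, no longer shows the effect seen with the unsubstituted ring at the one concentration tested. Nothing on hand bears on the reason for this step, so it stands as an observation on one pair.

Going by these compounds, what remains open is whether the loss belongs to methyl itself or would follow any group at this place, such as a methoxy group, an amine, a carboxylic acid or a longer chain such as ethyl. Also open, on these data alone, is whether methyl on another carbon of the same ring would give the same step, since this single pair speaks for one place and one group only.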